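This account rests on a few compounds, and the source may have more. Where it says the series, first, only, none or still open, it means among the compounds named here.

Compound 2 `N#CC1=C(NCC(=O)N2CCCC2)N(c2ccccc2)C(=O)N2CCCCC(N3CCCC3)C12` is the pyrrolidine amide of the acid compound 1 `N#CC1=C(NCC(=O)O)N(c2ccccc2)C(=O)N2CCCCC(N3CCCC3)C12`. In a functional assay on the whole organism (strain albino) for inhibition, with Rattus norvegicus as the target, read by paw edema, with a stated time of 1 h, at a dose of 20 mmol/kg by the intraperitoneal route (a higher number here means more inhibition at the dose given (going by the name of the read-out), a lower number less inhibition), compound 1 gives 67.2%, and in this assay compound 2 gives 40.1%. Among the compounds with values here, the only step so far, a number 27.1 percentage points lower from compound 1 to compound 2 (beyond the scatter), came from pyrrolidin-1-yl in place of hydroxy on a carbonyl carbon. On the two numbers available, compound 2 stands lowest, with compound 1 the nearest point and beyond the scatter above it.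

Compound 3 `N#CC1=C(NCN2CCCCC2)N(c2ccccc2)C(=O)N2CCCCC(N3CCCC3)C12` is the next point. Its change from compound 2 is piperidin-1-yl in place of (pyrrolidin-1-yl)carbonyl on a saturated chain carbon bound to an amine nitrogen. Within the data shown here, no measured step bears on this change directly: the one step in hand altered the same chain end, and it lowered inhibition by a modest amount when the hydroxy was exchanged for pyrrolidin-1-yl. Whether removing the carbonyl and shifting from a five-membered to a six-membered ring moves the number further cannot be read from that step, so no step beyond the scatter is expected in this assay, and a number 2.1 percentage points lower from compound 2 to compound 3 (within the scatter) is the expectation, held wide. In this assay compound 3 is estimated at 38%, with a range from 18% to 58%.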

Compound 3, a percentage reported as inhibition, in the whole organism at one dose (the size of the read-out at that dose, not a potency): 29.7%
Compound 3: the middle estimate sits 8.3 percentage points above what was measured, within the range that was stated.
By their numbers in this assay, from the lowest: compound 3; then compound 2; then compound 1.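

In this assay, piperidin-1-yl in place of (pyrrolidin-1-yl)carbonyl on this saturated chain carbon bound to an amine nitrogen gives a number 10.4 percentage points lower from compound 2 to compound 3 (beyond the scatter), so the number at this position still moves among chain ends that lack the carboxy, and the amide end of compound 2 does not mark the bottom of the range seen so far. Taken against the acid, piperidin-1-yl in place of carboxy gives a number 37.5 percentage points lower from compound 1 to compound 3 (beyond the scatter), the largest step in hand, which leaves compound 1 highest and compound 3 lowest of the three, with every gap among them beyond the scatter. This one change removes the carbonyl and exchanges a five-membered ring for a six-membered one at the same time, so the two cannot be told apart, and no supporting data bear on why the number fell.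

Open, going by these compounds, is which part of the change carries the step: a (piperidin-1-yl)carbonyl end would hold the carbonyl and change only the ring, while a pyrrolidin-1-yl end on the same carbon would do the reverse. Also open, on these data alone, is whether a methyl ester, or a carboxylic acid on a longer chain, stays with compound 1 or falls towards the amine-ended compounds.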